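The compounds below may be only part of what the source reports. "The series", "measured", "known", "first", "only" and "open" are said of these compounds alone.

Compound 1 `COc1ccc(CNCCCNS(=O)(=O)c2cc(C(F)(F)F)cc(C(F)(F)F)c2)cc1OC`: 2700 nM
Compound 2 `O=S(=O)(NCCCNCc1ccc(C(F)(F)F)cc1)c1cc(C(F)(F)F)cc(C(F)(F)F)c1`: 2900 nM

For the measured compounds named here, in a functional assay on HT-29 cells (Homo sapiens) for inhibition, read by MTT assay, with a stated time of 72 h (on this read-out higher numbers stand for weaker inhibition of growth and lower numbers for stronger inhibition of growth), compound 2 gives 2900 nM, and the only other number measured, that of compound 1, is separated from it by a 1.1-fold higher number from compound 1 to compound 2 (0.03 log units; within the scatter), so the two sit within the scatter of one another. Compound 3 `O=S(=O)(NCCCNCc1cccc2ccccc12)c1cc(C(F)(F)F)cc(C(F)(F)F)c1` has not yet been measured. It differs from compound 2 by naphthalen-1-yl in place of 4-(trifluoromethyl)phenyl on a saturated chain carbon bound to an amine nitrogen. Going by the values given here, the one measured step that bears on this place is a 1.1-fold higher number from compound 1 to compound 2 (0.03 log units; within the scatter), where swapping one aryl group for another on that same chain carbon left the number unchanged within the scatter. On that basis no step beyond the scatter is expected in this assay for compound 3, in either direction. The estimated change is no change at the digits printed from compound 2 to compound 3 (within the scatter). Compound 3 is therefore expected to give about 2900 nM, with a range from 1200 nM to 7000 nM.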

Compound 3, concentration for 50% growth inhibition: 2600 nM
Estimate against measurement, compound 3: 1.1-fold (0.05 log units) above, and the stated range covers the measured number.
By their numbers in this assay, from the lowest: compounds 3, 1 and 2 (each within the scatter of the next).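

In this assay the change to naphthalen-1-yl on the saturated chain carbon bound to an amine nitrogen gives a 1.1-fold lower number from compound 2 to compound 3 (0.05 log units; within the scatter) and a 1.0-fold lower number from compound 1 to compound 3 (0.02 log units; within the scatter). The earlier pair had compared only groups with one six-membered aromatic ring, whereas compound 3 carries two such rings and its number still stays within the scatter of both. Across these three compounds, the aryl group at this place therefore makes no difference beyond the scatter, and no measurement given here offers an explanation.

The compounds shown carry only carbon aromatic rings at this place, so it remains open whether a pyridin-3-yl or a cyclohexyl group would also leave the number within the scatter. On these data alone, the effect of a longer chain in the shared core also remains open.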